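The source may hold more compounds than are shown below. What is called first, only, known or untested is meant among the compounds shown, and "the series" means these compounds.

Measured in a functional assay on HFF cells (Homo sapiens) for cytotoxicity; on this read-out lower numbers stand for stronger inhibition and higher numbers for weaker inhibition:
compound 1 `O[C@@H]1[C@@H](CCl)OC(n2c(Cl)nc3cc(Cl)c(Cl)cc32)[C@@H]1O` gives 32000 nM
compound 2 `[N-]=[N+]=NC[C@H]1OC(n2c(Cl)nc3cc(Cl)c(Cl)cc32)[C@H](O)[C@@H]1O` gives 32000 nM
compound 3 `CC1(C)OC2C(CCl)OC(n3c(Cl)nc4cc(Cl)c(Cl)cc43)C2O1` gives 32000 nM

Compound 1 and compound 2 differ in one place: azido in place of chloro on a saturated chain carbon bound to a saturated ring carbon. That change produced no change at the digits printed from compound 1 to compound 2 (within the scatter). Compound 3 carries the chloromethyl of compound 1 on a different core; the difference between the two cores is not broken down here, and in this assay compound 3 sits level with compound 1 and compound 2 within the scatter.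

Compound 4 `CC1(C)OC2C(CN=[N+]=[N-])OC(n3c(Cl)nc4cc(Cl)c(Cl)cc43)C2O1` is not yet measured. It differs from compound 3 by azido in place of chloro on a saturated chain carbon bound to a saturated ring carbon, the same change as from compound 1 to compound 2, at the same place. Because no change at the digits printed from compound 1 to compound 2 (within the scatter) lay within the scatter, the expected step is no change at the digits printed from compound 3 to compound 4 (within the scatter) in this assay. Compound 4 is estimated at 32000 nM in this assay, between 16000 nM and 64000 nM.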

Compound 4, half-maximal inhibitory concentration: 32000 nM
Compound 4: the middle estimate sits on the measured number at the digits printed; the range from low to high includes it.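

In this assay, azidomethyl in place of chloromethyl gives no change at the digits printed from compound 3 to compound 4 (within the scatter), and the step reads alike on both cores: the same change on two cores in this assay, no change at the digits printed (within the scatter) from compound 1 to compound 2 and no change at the digits printed (within the scatter) from compound 3 to compound 4, 1.0-fold (0.00 log units) apart, within the scatter of two such steps.

Within these two pairs, the change therefore carries from one core to the other as a step within the scatter. Among the compounds shown here, this does not show that it would stay flat on any further core or in another read-out, since only two cores and one assay are covered, and all four compounds print the same value.

Open, going by these compounds, is whether a different group at this place, such as an amine, a carboxylic acid or a longer chain, would move the value from that shared level. Also open, on these data alone, is what separate part the difference between the two cores plays.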